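Aniline-ring variation on a shared core: notes toward compound 3

This account rests on a few compounds, and the source may have more. Where it says the series, first, only, none or still open, it means among the compounds named here.

Measured so far:
compound 1 `COc1ccccc1Nc1nc(SCc2cn(Cc3ccccc3Cl)nn2)nc(-c2ccccc2)c1C#N` — 7860 nM
compound 2 `Cc1cccc(Nc2nc(SCc3cn(Cc4ccccc4Cl)nn3)nc(-c3ccccc3)c2C#N)c1` — 13500 nM

Two compounds of the series have numbers in a functional assay on B16-F10 cells (Mus musculus) for inhibition, read by MTT assay, with a stated time of 72 h; on this read-out higher numbers stand for weaker inhibition and lower numbers for stronger inhibition. Compound 1 gives 7860 nM and compound 2 gives 13500 nM. Compound 2 has the highest of the two numbers; its nearest neighbour is compound 1, and the step of a 1.7-fold higher number from compound 1 to compound 2 (0.23 log units; within the scatter) lies within the scatter, so the two compounds are not separated on this read-out.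

Compound 3 `N#Cc1c(Nc2cccc([N+](=O)[O-])c2)nc(SCc2cn(Cc3ccccc3Cl)nn2)nc1-c1ccccc1` has not been measured. It differs from compound 2 in one place: nitro in place of methyl on an aromatic carbon. Among the measured compounds shown here, the single measured step bears on it only loosely: from compound 1 to compound 2 the group on the nitrogen on an aromatic ring was also exchanged, 3-methylphenyl in place of 2-methoxyphenyl, and that step stayed within the scatter. For the measured compounds named here, no measured pair exchanges methyl for nitro, so nothing shows how that exchange moves this assay. The working expectation is therefore a step of a 1.1-fold lower number from compound 2 to compound 3 (0.05 log units; within the scatter), not beyond the scatter. Compound 3 is expected to give about 12000 nM, within 4000 nM to 36000 nM.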

Compound 3, half-maximal inhibitory concentration: 17200 nM
For compound 3 the middle estimate is 1.4-fold (0.16 log units) below the measured one; measured number inside the range.
By their numbers in this assay, from the lowest: compounds 1, 2 and 3 (each within the scatter of the next, the first and the last beyond it).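

Nitro in place of methyl on the aromatic carbon gives a 1.3-fold higher number from compound 2 to compound 3 (0.11 log units; within the scatter) in this assay, so this exchange, with 3 heavy atoms and 2 hydrogen-bond acceptors entering where 1 heavy atom and none left, does not separate the two compounds. The series now has its first step beyond the scatter, though a modest one: 3-nitrophenyl in place of 2-methoxyphenyl on the nitrogen gives a 2.2-fold higher number from compound 1 to compound 3 (0.34 log units; beyond the scatter), while compound 2, with 3-methylphenyl, is separated from neither of the other two. Nothing on hand bears on why these numbers fall as they do.

The compounds shown do not tell whether the separation of compound 1 from compound 3 belongs to the place of the group on the phenyl ring or to the group itself, since 3-methoxyphenyl and 2-nitrophenyl do not appear among them. They also leave open how an amine or a carboxylic acid in place of methyl on that same aromatic carbon would read in this assay, and whether any such exchange would move the number beyond the scatter from compound 2.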